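From Piperazine Side Arm to Chlorophenyl Ethenyl Arm

A few compounds are considered here, and "the series" means these few. Any claim that something is new, unique, unknown or untested is made for them only; others in the source may bear on it.

Measured compounds:
Compound 1 `CN1CCN(Cc2nnc(-c3cc(S(N)(=O)=O)c(SCc4ccccc4)cc3Cl)o2)CC1`: 75000 nM
Compound 2 `[N-]=[N+]=NCc1nnc(-c2cc(S(N)(=O)=O)c(SCc3ccccc3)cc2Cl)o1`: 115000 nM
Compound 3 `CC(C)(O)c1cn(Cc2nnc(-c3cc(S(N)(=O)=O)c(SCc4ccccc4)cc3Cl)o2)nn1`: 68000 nM

All three were tested in a functional assay on HeLa cells (Homo sapiens) for cytotoxicity, read by MTT assay, with a stated time of 72 h; a lower number here means a stronger inhibitor, a higher number a weaker inhibitor. Compound 1 gives the second highest of the three numbers. Its nearest neighbour is compound 3, with a 1.1-fold lower number from compound 1 to compound 3 (0.04 log units; within the scatter), and its furthest is compound 2, with a 1.5-fold higher number from compound 1 to compound 2 (0.19 log units; within the scatter). The remaining pair shows a 1.7-fold lower number from compound 2 to compound 3 (0.23 log units; within the scatter). Every one of these steps lies within the scatter, so none of the three compounds can be called stronger or weaker than another; they sit together in a narrow band.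

Compound 4 `NS(=O)(=O)c1cc(-c2nnc(/C=C/c3cccc(Cl)c3)o2)c(Cl)cc1SCc1ccccc1` has not yet been measured. It differs from compound 1 in one place: 2-(3-chlorophenyl)ethenyl in place of (4-methylpiperazin-1-yl)methyl on an aromatic carbon

Within the data shown here, none of the measured steps bears directly on this change. Each of them only exchanges the group on the saturated chain carbon, and each stays within the scatter. What they do show is that varying this arm of the shared core has so far left the number in this assay almost unchanged. The expectation for compound 4 is therefore a number in the same broad region, with a wide margin for a shift in either direction; the estimated step is a 1.5-fold lower number from compound 1 to compound 4 (0.18 log units; within the scatter). Compound 4 is estimated at 50000 nM, within a range from 12000 nM to 160000 nM.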

Compound 4, half-maximal inhibitory concentration: 16000 nM
Estimate against measurement, compound 4: 3.1-fold (0.49 log units) above; measured number inside the range.
By their numbers in this assay, from the lowest: compound 4; then compounds 3, 1 and 2 (each within the scatter of the next).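

In this assay, among these compounds, putting 2-(3-chlorophenyl)ethenyl on the aromatic carbon of the five-membered ring gives the first steps in this set that lie beyond the scatter: a 4.7-fold lower number from compound 1 to compound 4 (0.67 log units; beyond the scatter), a 4.3-fold lower number from compound 3 to compound 4 (0.63 log units; beyond the scatter) and a 7.2-fold lower number from compound 2 to compound 4 (0.86 log units; beyond the scatter). The earlier exchanges of the group on the saturated chain carbon stayed within the scatter, whereas this larger change, which replaces the whole arm, shows that the number can respond to what is attached at this position, though each step is only modest. Nothing measured here explains which part of the new arm accounts for these steps.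

The change alters several things at once, removing the saturated chain carbon and the six-membered non-aromatic ring, and bringing in a double bond, a carbon-only aromatic ring and a chlorine, so these compounds cannot separate their contributions. As far as these compounds go, it remains open how a 2-phenylethenyl arm without the chlorine or a saturated 2-(3-chlorophenyl)ethyl chain would compare with compound 4 in this assay.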